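The source may report more compounds than this note shows. Statements on the series, on what has been measured and on what is new or still open speak of the compounds shown alone.

Compound 1, `Cc1nc(-c2ccccc2)c(C(=O)N2CCN(c3cccc(C#N)c3)CC2)o1`: 2.52 ug/mL
Compound 2, `COc1cc(OC)cc(N2CCN(C(=O)c3oc(C)nc3-c3ccccc3F)CC2)c1`: 0.118 ug/mL

In a toxicity assay on HUVEC cells (Homo sapiens) for inhibition (on this read-out lower numbers stand for stronger inhibition of growth and higher numbers for weaker inhibition of growth), compound 1 gives 2.52 ug/mL, the highest of the two numbers measured, meaning the weakest inhibition of growth. Its nearest neighbour, compound 2, gives 0.118 ug/mL, a much lower number, and that gap is beyond the usual scatter.

Compound 3, `COc1cc(OC)cc(N2CCN(C(=O)c3oc(C)nc3-c3ccccc3)CC2)c1`, has not yet been measured in this assay. It differs from compound 1 in one place: 3,5-dimethoxyphenyl in place of 3-cyanophenyl on an amine nitrogen in a ring. Compound 2 also bears a 3,5-dimethoxyphenyl group and gives a far lower number than compound 1, so the change is expected to move compound 3 toward stronger inhibition of growth.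

Within the data shown here, no step between two measured compounds of this exact kind is known, so the size is uncertain. Compound 3 is expected to fall between the two measured values, and the step of a 7.2-fold lower number from compound 1 to compound 3 (0.86 log units; beyond the scatter) is expected to be clearly beyond the scatter. The estimate for compound 3 is 0.35 ug/mL, in a range from 0.09 ug/mL to 1.3 ug/mL.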

Compound 3, concentration for 50% growth inhibition: 0.319 ug/mL
Compound 3: the middle estimate sits 1.1-fold (0.04 log units) above what was measured, within the range that was stated.
By their numbers in this assay, from the lowest: compound 2; then compound 3; then compound 1.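

In this assay, putting 3,5-dimethoxyphenyl in place of 3-cyanophenyl on the amine nitrogen in the ring, with the rest of the molecule unchanged, gives a 7.9-fold lower number from compound 1 to compound 3 (0.90 log units; beyond the scatter), so this single change is enough to strengthen growth inhibition clearly. Compound 3 also isolates a second change: with 3,5-dimethoxyphenyl held constant, hydrogen in place of fluoro on an aromatic carbon gives a 2.7-fold higher number from compound 2 to compound 3 (0.43 log units; beyond the scatter), which shows that the fluoro-bearing compound 2 inhibits growth more strongly and that this second position also affects the read-out. Nothing here measures why either change shifts the number, so the compounds show the size and direction of these steps but not their cause.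

On these data alone, it remains open whether both methoxy groups are needed, or whether a single methoxy, or a different group such as an amine or a carboxylic acid on that phenyl ring, would give a similar number. As far as these compounds go, it is also open whether the fluoro step would keep its direction and size alongside 3-cyanophenyl, since it has been seen here only alongside 3,5-dimethoxyphenyl.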